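A few compounds are considered here, and "the series" means these few. Any claim that something is new, unique, unknown or untested is made for them only; others in the source may bear on it.

Measured compounds:
- compound 1, `O=C(O)C1CCN(c2ccc(C(F)(F)F)cc2)C1`: 50000 nM
- compound 2, `O=C(O)C1CCN(c2ccc(F)cc2)C1`: 15000 nM

Among the compounds with values here, in an assay on cells for inhibition of Palmitoleoyl-protein carboxylesterase NOTUM variant C330S (Homo sapiens), read by fluorescence, with a stated time of 40 min (a lower number here means a stronger inhibitor, a higher number a weaker inhibitor), compound 2 gives the lower of the two numbers recorded so far; its nearest neighbour is compound 1, and the single change between them, fluoro in place of trifluoromethyl on an aromatic carbon, gives a 3.3-fold lower number from compound 1 to compound 2 (0.52 log units; beyond the scatter).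

Compound 3, `O=C(O)C1CCN(c2ccc(F)c(C(F)(F)F)c2)C1`, keeps the fluoro of compound 2 and adds a second group: trifluoromethyl in place of hydrogen on an aromatic carbon, ortho to a fluoro group and meta to the group of 8 heavy atoms.

Within the data shown here, only one measured step bears on this, and not directly: it shows that a trifluoromethyl where compound 1 carries it is paired with a higher number than the fluoro of compound 2 at the same carbon, by a 3.3-fold lower number from compound 1 to compound 2 (0.52 log units; beyond the scatter). Nothing in the set tells whether a trifluoromethyl at the new position, alongside the retained fluoro, behaves the same way. The expected step of a 1.3-fold higher number from compound 2 to compound 3 (0.12 log units; within the scatter) is therefore small, at most a modest rise, and may well fall within the scatter. Compound 3 is estimated at 20000 nM, with a range from 7000 nM to 60000 nM.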

Compound 3, half-maximal inhibitory concentration: 2500 nM
Beside the measured number, compound 3's estimate is 8.0-fold (0.90 log units) above it, outside the stated range (below it).
By their numbers in this assay, from the lowest: compound 3; then compound 2; then compound 1.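

On the shared core, trifluoromethyl in place of hydrogen on an aromatic carbon, ortho to a fluoro group and meta to a group of 8 heavy atoms, gives a 6.0-fold lower number from compound 2 to compound 3 (0.78 log units; beyond the scatter) in this assay, so this carbon takes a group of 4 heavy atoms with stronger inhibition. Trifluoromethyl therefore does not go with a higher number wherever it stands: where compound 1 carries it, the earlier step to a fluoro gives a 3.3-fold lower number from compound 1 to compound 2 (0.52 log units; beyond the scatter), so in these two steps the direction depends on the place of the group. Nothing available accounts for this difference between the two places.

The compounds shown leave open whether the lower number at this carbon needs the retained fluoro, and a trifluoromethyl at the same carbon with hydrogen in place of that fluoro would separate the two. Also open, as far as these compounds go, is how far the trend is specific to trifluoromethyl, as a chloro, methyl, methoxy or nitrile at this carbon would show, and whether the carboxylic acid can give way to an amide or a tetrazole.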